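A few compounds are considered here, and "the series" means these few. Any claim that something is new, unique, unknown or untested is made for them only; others in the source may bear on it.

Values so far in a functional assay on prostate cells (Homo sapiens) for antiproliferative activity; a lower number here means a stronger inhibitor of growth, a higher number a weaker inhibitor of growth
- compound 1 `N=C(N)N/N=C/c1c(-c2ccccn2)nc2sc(Cl)cn12` gives 9330 nM
- compound 2 `N=C(N)N/N=C/c1c(-c2cccnc2)nc2sc(Cl)cn12` gives 15100 nM
- compound 3 `N=C(N)N/N=C/c1c(-c2ccncc2)nc2sc(Cl)cn12` is not yet measured

Compound 2 stands level with compound 1 in this assay, the two lying within the scatter of each other. The next change is pyridin-4-yl in place of pyridin-3-yl on an aromatic carbon. For the measured compounds named here, the one measured step bearing on it is a similar swap, a 1.6-fold higher number from compound 1 to compound 2 (0.21 log units; within the scatter), and it stays within the scatter. No step beyond the scatter is therefore expected in this assay, in either direction. The expected step is a 1.3-fold lower number from compound 2 to compound 3 (0.10 log units; within the scatter). For compound 3 the estimate is 12000 nM, with an expected range from 6000 nM to 25000 nM.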

Compound 3, concentration for 50% growth inhibition: 17400 nM
Beside the measured number, compound 3's estimate is 1.5-fold (0.16 log units) below it; measured number inside the range.
By their numbers in this assay, from the lowest: compounds 1, 2 and 3 (each within the scatter of the next).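

In this assay, on this aromatic carbon, pyridin-4-yl in place of pyridin-3-yl gives a 1.2-fold higher number from compound 2 to compound 3 (0.06 log units; within the scatter), and pyridin-4-yl in place of pyridin-2-yl gives a 1.9-fold higher number from compound 1 to compound 3 (0.27 log units; within the scatter). With all three steps among compounds 1, 2 and 3 within the scatter, the place of the nitrogen in the pyridine ring has no readable effect on the number in this assay. No measured evidence on this result is available. From the compounds shown here alone, whether phenyl, which has no ring nitrogen, or morpholine on this carbon gives a step beyond the scatter stays open.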